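A few compounds are considered here, and "the series" means these few. Any claim that something is new, unique, unknown or untested is made for them only; others in the source may bear on it.

Compound 1 `O=C(/C=C\c1ccccc1O)N1N=C(c2ccncc2)OC1c1c[nH]c2ccccc12` gives 26.8 ug/mL in an ADME assay on HeLa cells (Homo sapiens) for cytotoxicity, read by MTT assay, with a stated time of 72 h; a higher number here means a weaker inhibitor of growth, a lower number a stronger inhibitor of growth.
Compound 2 `O=C(/C=C\c1cccc([N+](=O)[O-])c1)N1N=C(c2ccncc2)OC1c1c[nH]c2ccccc12` gives > 30 ug/mL in this assay, a limit of the assay rather than a number.
Compound 3 `O=C(/C=C\c1ccccc1F)N1N=C(c2ccncc2)OC1c1c[nH]c2ccccc12` gives > 30 ug/mL in this assay, likewise a limit.

Compound 3 therefore stands at the ceiling of the assay, where compound 2 also sits, while only compound 1 returns a number (the limit of > 30 ug/mL in this assay, at which 2 of the 3 values shown sit). Compound 4 `O=C(/C=C\c1cccc(Cl)c1)N1N=C(c2ccncc2)OC1c1c[nH]c2ccccc12` differs from compound 3 in one place: 3-chlorophenyl in place of 2-fluorophenyl on a double-bonded chain carbon bound to a double-bonded chain carbon. Going by the values given here, no measured step exchanges these two groups directly. The steps outward from compound 1 read an at least 1.1-fold higher number from compound 1 to compound 2 (0.04 log units; that floor lies within the scatter) and an at least 1.1-fold higher number from compound 1 to compound 3 (0.04 log units; that floor lies within the scatter), both floors within the scatter, and the step between the two limit compounds is a step that the two limits leave unreadable from compound 2 to compound 3. None of the three ring variants is separated from another beyond the scatter, so no shift beyond the scatter is expected in this assay. Compound 4 is expected at 35 ug/mL, range 18 ug/mL to 70 ug/mL, most probably reported again as a limit. The expected step is a step that the limit leaves unreadable from compound 3 to compound 4.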

Compound 4, concentration for 50% growth inhibition: > 30 ug/mL
Compound 4: no number, only a limit; the forecaster's own chance of this, stated with the estimate: 65%; the middle value lies beyond the limit too.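

In this assay the exchange of 2-hydroxyphenyl for 3-chlorophenyl gives an at least 1.1-fold higher number from compound 1 to compound 4 (0.04 log units; that floor lies within the scatter) at this place on the double-bonded chain carbon. The steps from compound 2 to compound 4 and from compound 3 to compound 4 cannot be read, so 3-chlorophenyl is not told apart from 3-nitrophenyl or 2-fluorophenyl here. A chlorine-bearing ring joins the nitro and fluoro variants at the ceiling: the limit of > 30 ug/mL in this assay, at which 3 of the 4 values shown sit.

From the compounds shown here alone, whether the variants at the limit differ from one another stays open. So does whether an amine, a carboxylic acid or a longer chain at this place would return a number in this assay.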